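Swapping one fused aromatic group for another

This account rests on a few compounds, and the source may have more. Where it says the series, first, only, none or still open, it means among the compounds named here.

Compound 2 `CC(=O)N1CCC(n2cc(-c3cnc(N)c4oc(-c5cccc6cnsc56)cc34)cn2)CC1` was tested in an ADME assay on microsomes from liver (Mus musculus) for metabolic stability (on this read-out lower numbers stand for lower hepatic extraction and higher numbers for higher hepatic extraction), where compound 2 gives 0.84. Among the compounds with values here, this is the highest of the two numbers known here; the only other measured compound, compound 1 `CC(=O)N1CCC(n2cc(-c3cnc(N)c4oc(-c5cccc6ccccc56)cc34)cn2)CC1`, gives 0.77 in this assay, and the step a number 0.070 higher from compound 1 to compound 2 (within the scatter) is too small to count as a real difference.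

Compound 3 `CC(=O)N1CCC(n2cc(-c3cnc(N)c4oc(-c5csc6ccccc56)cc34)cn2)CC1` has not yet been measured. It differs from compound 2 in one place: a group of 9 heavy atoms (8 carbon, 1 sulfur; one five-membered aromatic ring with 1 hetero atom, one six-membered aromatic ring of carbon only) in place of a group of 9 heavy atoms (7 carbon, 1 nitrogen, 1 sulfur; one five-membered aromatic ring with 2 hetero atoms, one six-membered aromatic ring of carbon only), on an aromatic carbon. The entering group sits on an aromatic carbon of a five-membered aromatic ring with 1 oxygen, part of a fused or bridged system of two rings, next to the ring oxygen, which is the same place where compound 1 and compound 2 already differ.

Within the data shown here, only that earlier step bears on the present change: there too a group of two aromatic rings replaced another of similar size at this place, and a number 0.070 higher from compound 1 to compound 2 (within the scatter) stayed within the scatter. The exchange of one such group for another is therefore expected to move the read-out little, if at all. The expected step of no change at the digits printed from compound 2 to compound 3 (within the scatter) lies within the scatter. In this assay compound 3 is estimated at 0.84, with a likely range from 0.72 to 0.93.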

Compound 3, hepatic extraction ratio: 0.85
Compound 3: the middle estimate sits 0.010 below what was measured, and the stated range covers the measured number.
By their numbers in this assay, from the lowest: compounds 1, 2 and 3 (each within the scatter of the next).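

In this assay, 1-benzothiophen-3-yl on this aromatic carbon, next to the ring oxygen, gives a number 0.010 higher from compound 2 to compound 3 (within the scatter) when it replaces the group that carries both nitrogen and sulfur in its five-membered ring. The same group in place of naphthalen-1-yl gives a number 0.080 higher from compound 1 to compound 3 (within the scatter) and thus adds a second comparison with the all-carbon group. Three fused aromatic groups now lie within the scatter of one another, so in these compounds neither nitrogen nor sulfur in the group gives a readable change, and compound 3 at 0.85 still stands with the other two in this narrow band. Nothing available here explains why these groups give such similar numbers.

From the compounds shown here alone, what stays open is whether a group of another kind at this place, such as a simple amine, a carboxylic acid or a short alkyl chain, would move the hepatic extraction ratio beyond the scatter. Going by these compounds, it is also open whether a change elsewhere on the shared core would do so, since all three compounds differ only at this one place.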